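Nitro in Place of Chloro: Expected Cytotoxicity of Compound 4

This account rests on a few compounds, and the source may have more. Where it says the series, first, only, none or still open, it means among the compounds named here.

Three measured compounds share one core and differ only in the substituent on the phenyl ring attached to the double bond. In an ADME assay on cells (Macrophage, Homo sapiens) for cytotoxicity, read by MTT assay, with a stated time of 24 h (on this read-out lower numbers stand for higher toxicity in this test and higher numbers for lower toxicity in this test), compound 1 `COc1ccccc1/C=C/c1ncc([N+](=O)[O-])n1CC(C)O` gives 480 nM. Compound 2 `CC(O)Cn1c([N+](=O)[O-])cnc1/C=C/c1cccc(Br)c1` gives 620 nM in this assay. Compound 3 `CC(O)Cn1c([N+](=O)[O-])cnc1/C=C/c1ccccc1Cl` gives 480 nM in this assay, level with compound 1 at the digits shown and, together with it, the lowest of the three numbers; the gap to compound 2 stays within the scatter.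

Two measured steps lead to compound 3. Swapping methoxy for chloro gives no change at the digits printed from compound 1 to compound 3 (within the scatter). Swapping 3-bromophenyl for 2-chlorophenyl gives a 1.3-fold lower number from compound 2 to compound 3 (0.11 log units; within the scatter). Neither moves the read-out beyond the scatter.

Compound 4 `CC(O)Cn1c([N+](=O)[O-])cnc1/C=C/c1ccccc1[N+](=O)[O-]` differs from compound 3 by nitro in place of chloro on an aromatic carbon. For the measured compounds named here, no measured pair swaps chloro for nitro, so the expectation rests on the two steps above, in which changing the substituent on this ring left the number essentially unchanged. The step from compound 3 to compound 4 is therefore expected to be no change at the digits printed from compound 3 to compound 4 (within the scatter), within the scatter. Compound 4 is estimated at 480 nM, with a range from 240 nM to 960 nM.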

Compound 4, half-maximal cytotoxic concentration: 1090 nM
Compound 4: middle estimate off by 2.3-fold (0.36 log units), on the low side, and the stated range ends below it.
By their numbers in this assay, from the lowest: compounds 1, 3, 2 and 4 (each within the scatter of the next, the first and the last beyond it).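

In this assay, for the compounds shown here, nitro in place of chloro gives a 2.3-fold higher number from compound 3 to compound 4 (0.36 log units; beyond the scatter), and nitro in place of methoxy gives a 2.3-fold higher number from compound 1 to compound 4 (0.36 log units; beyond the scatter), so these are the first changes on this ring that reach beyond the scatter. The aromatic carbon ortho to a large group is therefore not indifferent to what it carries: methoxy and chloro there cannot be told apart, whereas nitro stands apart from both, in the direction of lower toxicity in this test. Nothing measured among these compounds accounts for this shift.

The compounds shown leave open whether other groups at this same carbon, such as an amine, a carboxylic acid or a nitrile, would stay level with chloro and methoxy or move the number as nitro does. They also leave open whether nitro would give a similar step at the ring position held by bromo in the 3-bromophenyl of compound 2, so the effect cannot yet be separated from this one place on the ring.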